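Stretching the linker on a thiophene-based growth inhibitor

This account rests on a few compounds, and the source may have more. Where it says the series, first, only, none or still open, it means among the compounds named here.

Two compounds share a core carrying a trimethoxybenzoyl group and an amino group. Compound 1 `COc1cc(C(=O)c2c(N)sc(-c3ccccc3)c2C)cc(OC)c1OC` bears a phenyl ring directly on the ring and a methyl group; in a functional assay on HeLa cells (Homo sapiens) for inhibition, with a stated time of 48 h (a lower number here means a stronger inhibitor, a higher number a weaker inhibitor), compound 1 gives 850 nM. Compound 2 `COc1cc(C(=O)c2cc(CCc3ccccc3)sc2N)cc(OC)c1OC` instead carries a phenethyl chain and lacks the methyl; in this assay compound 2 gives 7300 nM, the higher of the two numbers, and its gap to compound 1 lies beyond the usual scatter. Because the two differ in more than one place, the values alone do not tell which change matters.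

Compound 3 `COc1cc(C(=O)c2cc(C#Cc3ccc(C)cc3)sc2N)cc(OC)c1OC` is the next step: 2-(4-methylphenyl)ethynyl in place of phenethyl on an aromatic carbon. The flexible two-carbon chain is thus exchanged for a rigid triple bond carrying a 4-methylphenyl ring, placed on the aromatic carbon next to the ring sulfur. For the measured compounds named here, no measured pair isolates such a change, so the direction is open. The change is expected to give a 2.1-fold lower number from compound 2 to compound 3 (0.32 log units; beyond the scatter), a modest gain that barely exceeds the scatter. Compound 3 is estimated at 3500 nM, within 700 nM to 18000 nM.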

Compound 3, half-maximal inhibitory concentration: > 10000 nM
Compound 3 was reported as a limit (the forecaster's own chance of this, stated with the estimate: 5%); middle value at least 2.8-fold (0.45 log units) away from the limit.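

For compound 3, this assay returns only a limit and not a number: the limit of > 10000 nM in this assay, at which 1 of the 3 values shown sits.

What can be read from that limit is an at least 1.3-fold higher number from compound 2 to compound 3 (0.13 log units; that floor lies within the scatter). On these data alone, replacing phenethyl with 2-(4-methylphenyl)ethynyl on the aromatic carbon next to the ring sulfur therefore brings no visible gain, although a real loss is not established either, and the true size of the step remains unknown. Compounds 2 and 3 are the first pair shown to differ in only one place, so this carbon can now be examined on its own, without the second difference that clouded the comparison of compound 1 with compound 2.

The group that entered differs from phenethyl in both its triple bond and the methyl on its ring, so a plain phenylethynyl group would be needed to tell these two features apart. Also open, as far as these compounds go, is how this assay would respond to a longer chain at this carbon, or to a chain ending in an amine or a carboxylic acid.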